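From phenyl to (pyridin-4-yl)methyl: compound 2 to compound 4

A few compounds are considered here, and "the series" means these few. Any claim that something is new, unique, unknown or untested is made for them only; others in the source may bear on it.

In an ADME assay on L02 cells (Homo sapiens) for inhibition, read by CCK-8 assay, with a stated time of 48 h (a lower number here means a stronger inhibitor of growth, a higher number a weaker inhibitor of growth), compound 2 `Cc1ccccc1Nc1nc(Nc2ccccc2)ncc1Cl` gives > 100000 nM, which is a limit of the assay. Compound 1 `Cc1ccccc1Nc1nc(NC2CCCCC2)ncc1Cl` gives > 100000 nM, also a limit. Compound 3 `Cc1ccccc1Nc1nc(Nc2ccccn2)ncc1Cl` gives 6150 nM.

Compound 4 `Cc1ccccc1Nc1nc(NCc2ccncc2)ncc1Cl` has (pyridin-4-yl)methyl in place of phenyl on a nitrogen on an aromatic ring.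

The closest measured change is an at least 16-fold lower number from compound 2 to compound 3 (1.21 log units; beyond the scatter), with pyridin-2-yl in place of phenyl. A second change, an at least 16-fold lower number from compound 1 to compound 3 (1.21 log units; beyond the scatter), also enters pyridin-2-yl. The third, a step that the two limits leave unreadable from compound 1 to compound 2, adds nothing.

The entering group differs from that of compound 3, so a smaller move in the same direction is expected in this assay: an at least 2.5-fold lower number from compound 2 to compound 4 (0.39 log units; beyond the scatter). For compound 4 the estimated value is 40000 nM, with an expected range of 9000 nM to 150000 nM.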

Compound 4, concentration for 50% growth inhibition: > 100000 nM
Compound 4: no number, only a limit; the forecaster's own chance of this, stated with the estimate: 45%; middle value at least 2.5-fold (0.39 log units) from the limit.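

Compound 4 gives > 100000 nM in this assay, a limit of the assay and not a number. With (pyridin-4-yl)methyl in place of pyridin-2-yl there is an at least 16-fold higher number from compound 3 to compound 4 (1.21 log units; beyond the scatter) and the measurable value of compound 3 is lost. The steps from compound 1 and from compound 2 to compound 4 cannot be read, and a ring nitrogen in the entering group does not alone bring a value under the limit: the limit of > 100000 nM in this assay, at which 3 of the 4 values shown sit.

Open, from the compounds shown here alone, is whether the methyl link or the place of the ring nitrogen separates compound 4 from compound 3. Pyridin-4-yl or (pyridin-2-yl)methyl on this nitrogen would tell the two apart.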